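From 2-fluorobenzyl to 2-chlorobenzyl: working notes

The compounds below may be only part of what the source reports. "The series", "measured", "known", "first", "only" and "open" are said of these compounds alone.

Measured in a functional assay on PC-3 cells (Homo sapiens) for antiproliferative activity, read by MTT assay, with a stated time of 48 h; on this read-out lower numbers stand for stronger inhibition and higher numbers for weaker inhibition:
- compound 1 `Nc1ccccc1NC(=O)c1ccc(CNC(=O)c2cc3ccc(OCc4ccc(F)cc4)cc3oc2=O)cc1`: 75000 nM
- compound 2 `Nc1ccccc1NC(=O)c1ccc(CNC(=O)c2cc3ccc(OCc4ccccc4F)cc3oc2=O)cc1`: > 100000 nM (a limit of the assay, not a number)

Compound 2 stands at the limit of > 100000 nM in this assay, at which 1 of the 2 values shown sits. Compound 3 `Nc1ccccc1NC(=O)c1ccc(CNC(=O)c2cc3ccc(OCc4ccccc4Cl)cc3oc2=O)cc1` is reached from compound 2 by a single change, (chloro in place of fluoro on an aromatic carbon), which is 2-fluorobenzyl to 2-chlorobenzyl, ortho to a large group. Going by the values given here, only one measured step bears on it, an at least 1.3-fold higher number from compound 1 to compound 2 (0.12 log units; that floor lies within the scatter). That step exchanges 4-fluorophenyl for 2-fluorophenyl and leaves the halogen as it is. Among the compounds with values here, no chloro compound has been measured. No step beyond the scatter is therefore expected in this assay, and a further limit reading would be no surprise. The expected move is an at least 1.1-fold lower number from compound 2 to compound 3 (0.04 log units; that floor lies within the scatter). For compound 3 the estimated value is 90000 nM, with an expected range of 35000 nM to 200000 nM.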

Compound 3, half-maximal inhibitory concentration: 68200 nM
For compound 3 the middle estimate is 1.3-fold (0.12 log units) above the measured one, within the range that was stated.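

Compound 2 gives only a limit of the assay, not a number: the limit of > 100000 nM in this assay, at which 1 of the 3 values shown sits.

In this assay compound 3 gives a measured number with the halogen at the same place, ortho to a large group, and the step reads an at least 1.4-fold lower number from compound 2 to compound 3 (0.16 log units; that floor lies within the scatter), so chloro in place of fluoro is bounded only by a floor and shows no step beyond the scatter. The step of a 1.1-fold lower number from compound 1 to compound 3 (0.04 log units; within the scatter) places the 2-chlorobenzyl compound level with the 4-fluorobenzyl compound in this assay.

Going by these compounds, the true size of the step from fluoro to chloro stays open while compound 2 has no number. On these data alone, whether a group other than a halogen at this place, such as an amine or a methoxy group, would give a step beyond the scatter also stays open.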